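Swapping the ring on compound 3: a pyrimidinylamino variant

A few compounds are considered here, and "the series" means these few. Any claim that something is new, unique, unknown or untested is made for them only; others in the source may bear on it.

Compound 1 `Cc1cc(-c2ccco2)c(S(C)(=O)=O)cc1C(=O)N=C(N)N`: 16 nM
Compound 2 `CCCSc1cc(C)c(C(=O)N=C(N)N)cc1S(C)(=O)=O`: 6.8 nM
Compound 3 `Cc1cc(N2CCCC(O)C2)c(S(C)(=O)=O)cc1C(=O)N=C(N)N`: 30 nM

Compound 3 gives the highest of the three numbers in a functional assay for inhibition of sodium/hydrogen exchanger (Oryctolagus cuniculus); a higher number here means a weaker inhibitor, a lower number a stronger inhibitor. It differs from compound 1 by a 1.9-fold higher number from compound 1 to compound 3 (0.27 log units; within the scatter) and from compound 2 by a 4.4-fold higher number from compound 2 to compound 3 (0.64 log units; beyond the scatter). Compound 4 `Cc1cc(Nc2ncccn2)c(S(C)(=O)=O)cc1C(=O)N=C(N)N` carries (pyrimidin-2-yl)amino in place of 3-hydroxypiperidin-1-yl on an aromatic carbon. Going by the values given here, no measured step ends in a (pyrimidin-2-yl)amino group, so the only guidance is that the two groups measured in place of 3-hydroxypiperidin-1-yl gave lower numbers, one within the scatter and one modestly beyond it. The number for compound 4 is therefore expected to come out somewhat lower, with a 1.7-fold lower number from compound 3 to compound 4 (0.22 log units; within the scatter), though a result inside the scatter would not surprise. The estimate for compound 4 is 18 nM, in a range from 6 nM to 55 nM.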

Compound 4, half-maximal inhibitory concentration: 8.3 nM
Compound 4: middle estimate off by 2.2-fold (0.34 log units), on the high side; low and high end bracket the measured number.
By their numbers in this assay, from the lowest: compounds 2, 4, 1 and 3 (each within the scatter of the next, the first and the last beyond it).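

With the 3-hydroxypiperidin-1-yl group replaced by (pyrimidin-2-yl)amino, a group of equal heavy-atom count, the number in this assay moves beyond the scatter (a 3.6-fold lower number from compound 3 to compound 4 (0.56 log units; beyond the scatter)), so that count alone does not set the result at this position. The new group stays within the scatter of both propylsulfanyl (a 1.2-fold higher number from compound 2 to compound 4 (0.09 log units; within the scatter)) and furan-2-yl (a 1.9-fold lower number from compound 1 to compound 4 (0.29 log units; within the scatter)). Nothing available explains the shift.

As far as these compounds go, it remains open whether the ring nitrogens matter, which a phenylamino group would test. A plain dimethylamino group would show whether the aromatic ring is needed at all.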